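Pyridin-2-yl in Place of 3-Methylphenyl on a Shared Core

This account rests on a few compounds, and the source may have more. Where it says the series, first, only, none or still open, it means among the compounds named here.

Compound 1: `Cc1cccc(-c2cc(-c3ccc(Cl)o3)cc(-c3ccsc3)n2)c1` — 20300 nM
Compound 2: `Clc1ccc(-c2cc(-c3cccs3)nc(-c3ccccc3Cl)c2)o1` — 18500 nM

In a functional assay on HeLa cells (Homo sapiens) for cytotoxicity, in the presence of a further agent that is not named here (a lower number here means a stronger inhibitor, a higher number a weaker inhibitor), compound 1 gives 20300 nM, and compound 2 gives 18500 nM. These two numbers lie within the usual scatter of each other, so nothing sets compound 1 apart from compound 2; both are weak. Compound 3 is `Clc1ccc(-c2cc(-c3ccsc3)nc(-c3ccccn3)c2)o1`, and it differs from compound 1 in one place: pyridin-2-yl in place of 3-methylphenyl on an aromatic carbon. Going by the values given here, no pair of measured compounds shows what this change does, so there is no measured step to lean on. In this assay the expected step is a 1.0-fold lower number from compound 1 to compound 3 (0.01 log units; within the scatter), that is, none beyond the scatter. Compound 3 is therefore estimated at 20000 nM, with a range from 6000 nM to 60000 nM.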

Compound 3, half-maximal inhibitory concentration: 22500 nM
The estimate for compound 3 lay 1.1-fold (0.05 log units) below the measured number; the measured number falls inside the stated range.
By their numbers in this assay, from the lowest: compounds 2, 1 and 3 (each within the scatter of the next).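

In this assay, the step at this position, next to the ring nitrogen of the shared core, is a 1.1-fold higher number from compound 1 to compound 3 (0.04 log units; within the scatter). Replacing a carbon-only ring bearing a methyl with pyridin-2-yl, which adds a hydrogen-bond acceptor, therefore shows no effect beyond the scatter, and compound 3 remains weak. No measured data explain why this change has so little effect. Still open, from the compounds shown here alone, is whether an aminomethyl group, a carboxylic acid or a longer alkyl chain at this position would shift the number beyond the scatter.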